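Swapping chloro for methyl on a methylated oxime

A few compounds are considered here, and "the series" means these few. Any claim that something is new, unique, unknown or untested is made for them only; others in the source may bear on it.

Compound 1 `O/N=C(/CCN1CCN(c2ccccn2)CC1)c1ccccc1Cl` and compound 2 `Cc1ccccc1/C(CCN1CCN(c2ccccn2)CC1)=N\O` share one core and differ at a single spot: methyl in place of chloro on an aromatic carbon. In a functional assay on HEK293 cells with D(4) dopamine receptor (Homo sapiens) as the target, read by FLIPR (on this read-out lower numbers stand for smaller maximal responses and higher numbers for larger maximal responses), compound 1 gives 64%, and compound 2 gives 72%. The change itself brings a number 8 percentage points higher from compound 1 to compound 2 (within the scatter), so the two values cannot be told apart with confidence.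

Compound 3 `CO/N=C(\CCN1CCN(c2ccccn2)CC1)c1ccccc1Cl` stands on a different core; how its core differs from that of compound 1 is not broken down here. In this assay compound 3 gives 79%.

Compound 4 `CO/N=C(\CCN1CCN(c2ccccn2)CC1)c1ccccc1C` has not yet been measured. Next to compound 3 it shows the same change that leads from compound 1 to compound 2: methyl in place of chloro on an aromatic carbon. Because the earlier step was a number 8 percentage points higher from compound 1 to compound 2 (within the scatter), the step from compound 3 to compound 4 is expected to be of similar small size, namely a number 6 percentage points higher from compound 3 to compound 4 (within the scatter). For compound 4 the maximal response in this assay is therefore estimated at 85%, with a likely range from 70% to 100%.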

Compound 4, largest response reached (reported as efficacy), in percent of the reference or control that the assay uses: 80%
Compound 4: the middle estimate sits 5 percentage points above what was measured; the range from low to high includes it.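

In this assay, putting methyl in place of chloro on the core of compound 3 gives a number 1 percentage points higher from compound 3 to compound 4 (within the scatter), so the two compounds cannot be told apart on this read-out. Set beside the same swap on the core of compound 1, the new step gives no sign that the change behaves differently on the two cores: the same change on two cores in this assay, a number 8 percentage points higher (within the scatter) from compound 1 to compound 2 and a number 1 percentage points higher (within the scatter) from compound 3 to compound 4, 7 percentage points apart, within the scatter of two such steps This shows only that the swap left no clear mark on the maximal response on either core; it does not show that a larger effect would carry across, or that the same would hold on a third core.

The compounds shown leave open what a different group on that aromatic carbon would do, such as methoxy, trifluoromethyl or a plain hydrogen. They also leave open whether the swap would read the same with a longer chain, such as ethyl, in place of the methyl on the oxime oxygen.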